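The compounds below may be only part of what the source reports. "The series", "measured", "known", "first", "only" and "open" are said of these compounds alone.

Two members of the series have been measured in a functional assay on HepG2 cells (Homo sapiens) for antiproliferative activity, read by MTT assay, with a stated time of 48 h; a higher number here means a weaker inhibitor, a lower number a stronger inhibitor. Compound 1 `Cc1ccc(-n2nncc2CN2C(=O)C3(C(C#N)=C(N)Oc4c(N)cc5nc6ccccc6nc5c43)c3ccccc32)cc1C` gives only a limit there, > 50000 nM. Compound 2 `Cc1cc(C)cc(-n2nncc2CN2C(=O)C3(C(C#N)=C(N)Oc4c(N)cc5nc6ccccc6nc5c43)c3ccccc32)c1` likewise gives only a limit, > 50000 nM. Among the compounds with values here, the one step between measured compounds, a step that the two limits leave unreadable from compound 1 to compound 2, is therefore unreadable, since both values sit at the limit of > 50000 nM in this assay, at which 2 of the 2 values shown sit. Compound 2 thus stands at the limit, with no number of its own in hand.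

Compound 3 `N#CC1=C(N)Oc2c(N)cc3nc4ccccc4nc3c2C12C(=O)N(Cc1cnnn1-c1c(Cl)cc(Cl)cc1Cl)c1ccccc12` is not yet measured. It differs from compound 2 by 2,4,6-trichlorophenyl in place of 3,5-dimethylphenyl on an aromatic nitrogen. Within the data shown here, no measured step bears on this change: the only step in hand runs between two limits and sets no size in either direction. With both measured neighbours at the limit, compound 3 is expected to come out at that same limit, so that a number no higher from compound 2 to compound 3 (the limit leaves the size open) is expected to show no step beyond the scatter. The estimate for compound 3 in this assay is 50000 nM, within 20000 nM to 150000 nM, with a limit the more likely outcome.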

Compound 3, half-maximal inhibitory concentration: 37800 nM
Compound 3: middle estimate off by 1.3-fold (0.12 log units), on the high side; low and high end bracket the measured number.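

In this assay, compound 3 alone among the three carries a number rather than a limit, so 2,4,6-trichlorophenyl on the aromatic nitrogen is the first group at this position to give a readable value, while the two dimethylphenyl compounds stay at the limit: the limit of > 50000 nM in this assay, at which 2 of the 3 values shown sit.

The change gives an at least 1.3-fold lower number from compound 2 to compound 3 (0.12 log units; that floor lies within the scatter) and an at least 1.3-fold lower number from compound 1 to compound 3 (0.12 log units; that floor lies within the scatter). Going by these compounds, both are floors set by limits, so the real size of the step remains unknown.

The step between the two dimethylphenyl compounds cannot be read, so nothing is known about how methyl placement on this ring acts. Within the data shown here, also open is whether a single chlorine, a methoxy group or an amine on this phenyl ring would give a number, and how that number would compare with the one for compound 3.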